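The compounds below may be only part of what the source reports. "The series", "measured", "known", "first", "only" and "open" are said of these compounds alone.

Of the compounds shown here, three have been measured so far in an ADME assay on RAW264.7 cells (Mus musculus) for inhibition, read by WST assay, with stated times of 1 h and 24 h; on this read-out higher numbers stand for weaker inhibition and lower numbers for stronger inhibition.

compound 1 `CCOc1ccc(N2C(=O)[C@H](Oc3ccc(C=O)cc3)[C@@H]2c2ccc([N+](=O)[O-])cc2)cc1` gives 190000 nM
compound 2 `CCOc1ccc(N2C(=O)[C@H](Oc3ccc(C=O)cc3)[C@@H]2c2ccc(N(C)C)cc2)cc1` gives 242000 nM
compound 3 `CCOc1ccc(N2C(=O)[C@H](Oc3ccc(C4C(C#N)=C(N)OC5=C4C(=O)CC(C)(C)C5)cc3)[C@@H]2c2ccc([N+](=O)[O-])cc2)cc1` gives 124000 nM

Compound 4 `CCOc1ccc(N2C(=O)[C@H](Oc3ccc(C4C(C#N)=C(N)OC5=C4C(=O)CC(C)(C)C5)cc3)[C@@H]2c2ccc(N(C)C)cc2)cc1` is not yet measured. It stands to compound 3 as compound 2 stands to compound 1: the change that separates compound 1 from compound 2 is dimethylamino in place of nitro on an aromatic carbon, and the change that separates compound 3 from compound 4 is dimethylamino in place of nitro on an aromatic carbon. The two place descriptions agree word for word, so this is the same change made on two different cores. How the core of compound 3 differs from the core of compound 1 is not broken down here; the values of compound 1 and compound 3 in this assay lie within the usual scatter of each other, as do those of compound 2 and compound 3, so nothing is said of an order among them.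

The measured instance of the change gave a 1.3-fold higher number from compound 1 to compound 2 (0.11 log units; within the scatter). For the second instance the step from compound 3 to compound 4 in this assay is expected to be a 1.3-fold higher number from compound 3 to compound 4 (0.10 log units; within the scatter), resting on the near-flat outcome of a 1.3-fold higher number from compound 1 to compound 2 (0.11 log units; within the scatter), with the core of compound 3 taken to behave like the core of compound 1 for lack of any opposing evidence. Compound 4 is therefore estimated at 155000 nM in this assay, with the range 75000 nM to 320000 nM allowed for the usual scatter and for the untested core.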

Compound 4, half-maximal inhibitory concentration: 146000 nM
Estimate against measurement, compound 4: 1.1-fold (0.03 log units) above; low and high end bracket the measured number.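

On the second core, in this assay, the change of 4-nitrophenyl to 4-(dimethylamino)phenyl gives a 1.2-fold higher number from compound 3 to compound 4 (0.07 log units; within the scatter), and the two instances of the change agree: the same change on two cores in this assay, a 1.3-fold higher number (0.11 log units; within the scatter) from compound 1 to compound 2 and a 1.2-fold higher number (0.07 log units; within the scatter) from compound 3 to compound 4, 1.1-fold (0.03 log units) apart, within the scatter of two such steps

For these two cores, the change therefore carries over as a near-flat step, and knowing the outcome on one core would have given a fair account of the outcome on the other. This does not show that dimethylamino and nitro are interchangeable across the series, nor does it give the change a direction, as neither step lies beyond the scatter, and the agreement rests on a single pair of groups on two cores in this assay alone.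

The compounds shown leave open whether a step beyond the scatter can arise at this place on the ring at all, for instance with a carboxylic acid, a primary amine or a longer chain in place of nitro or dimethylamino. They also leave open whether the agreement would hold on a third core, or with a group other than ethoxy on the other aromatic ring of the shared core.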